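A few compounds are considered here, and "the series" means these few. Any claim that something is new, unique, unknown or untested is made for them only; others in the source may bear on it.

Of the compounds shown here, two have been measured in an ADME assay (liver) for metabolic stability, with Liver microsome (Homo sapiens) as the target, using microsomes; a lower number here means that the compound disappears faster, a higher number that the compound lasts longer. Compound 1 (`Cc1nc2ccc(Cl)cn2c1C(=O)NCc1ccc(-c2ccccc2)cc1`) gives > 2 h, which is a limit of the assay and not a number. Compound 2 (`CCc1nc2cc(Cl)ccn2c1C(=O)NCc1ccc(-c2ccc(Cl)cc2)cc1`) gives > 2 h, which is likewise a limit of the assay. Compound 2 therefore has no exact half-life to start from, and all that the data offer so far is the limit of > 2 h in this assay, at which 2 of the 2 values shown sit. Among the compounds with values here, the two measured compounds differ in more than one place, so no measured step is available as a guide to the next change.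

Compound 3 (`CCc1nc2cc(Cl)ccn2c1C(=O)NCc1ccc(-c2ccncc2)cc1`) carries pyridin-4-yl in place of 4-chlorophenyl on an aromatic carbon, para to a large group: pyridin-4-yl in place of 4-chlorophenyl on an aromatic carbon. In this assay, a modest shortening of the half-life is expected, or no change beyond the scatter, and compound 3 may well be reported only as a limit too. The expected step is an at least 1.1-fold lower number from compound 2 to compound 3 (0.04 log units; that floor lies within the scatter). For compound 3 the estimated half-life is 1.8 h, with an expected range from 0.7 h to 3 h.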

Compound 3, half-life: 0.482 h
Compound 3: the middle estimate sits 3.7-fold (0.57 log units) above what was measured; measured number outside the range, below it.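

Setting pyridin-4-yl in place of 4-chlorophenyl, on an aromatic carbon para to a large group, brings an at least 4.1-fold lower number from compound 2 to compound 3 (0.61 log units; beyond the scatter) in this assay. This is the only step shown between compounds that differ in one place, and compound 3 is the only compound here with an exact half-life, so this position now has a visible bearing on the read-out, which the two earlier compounds could not show. The size of the step is only a floor, as the value of compound 2 is a limit of the assay and not a number: the limit of > 2 h in this assay, at which 2 of the 3 values shown sit.

The compounds shown leave open how much of the step goes with the ring nitrogen that enters and how much with the chlorine that leaves, since the change replaces both at once and compound 1, with its plain phenyl, differs from compound 3 in more than one place. Also open, on these data alone, is where pyridin-3-yl or 4-fluorophenyl would fall at this place, and whether the step would hold on a shared core with a different substitution pattern.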